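Replacing 5-chloro-2-methoxyphenyl with 3-propoxyphenyl: expected clearance

This account rests on a few compounds, and the source may have more. Where it says the series, first, only, none or still open, it means among the compounds named here.

In an in vitro ADME assay on microsomes from liver (Homo sapiens) for metabolic stability, using NADPH (a lower number here means slower removal, a higher number faster removal of the compound), three compounds on a shared core have been measured so far. Compound 2 (`COc1ccc(Cl)cc1Cn1c(C(=O)NCC(C)(C)CO)cc2cc(C#N)ccc21`) gives 83 mL.min-1.g-1 and lies within the scatter of compound 1 (`CCOc1ccc(OC(F)(F)F)cc1Cn1c(C(=O)NCC(C)(C)CO)cc2cc(C#N)ccc21`) at 103 mL.min-1.g-1 in this series. Compound 3 (`Cc1ccc(C(F)(F)F)cc1Cn1c(C(=O)NCC(C)(C)CO)cc2cc(C#N)ccc21`) at 180 mL.min-1.g-1 stands higher than compound 2 by more than the scatter. No two of these compounds differ in one place only, so no measured step isolates a single change.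

Compound 4 (`CCCOc1cccc(Cn2c(C(=O)NCC(C)(C)CO)cc3cc(C#N)ccc32)c1`) carries 3-propoxyphenyl in place of 5-chloro-2-methoxyphenyl on a saturated chain carbon bound to an aromatic nitrogen. For the measured compounds named here, none of the measured compounds carries 3-propoxyphenyl, so the only guide is the spread of the measured values, from compound 2 at 83 mL.min-1.g-1 to compound 3 at 180 mL.min-1.g-1 in the same read-out. Compound 4 is expected to fall in that same region. The expected step in this assay is upward but stays within the scatter (a 1.7-fold higher number from compound 2 to compound 4 (0.23 log units; within the scatter)). For compound 4 the value is estimated at 140 mL.min-1.g-1 (expected range 75 mL.min-1.g-1 to 260 mL.min-1.g-1).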

Compound 4, intrinsic clearance in microsomes: 156 mL.min-1.g-1
For compound 4 the middle estimate is 1.1-fold (0.05 log units) below the measured one; low and high end bracket the measured number.
By their numbers in this assay, from the lowest: compounds 2, 1, 4 and 3 (each within the scatter of the next, the first and the last beyond it).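

In this assay, 3-propoxyphenyl in place of 5-chloro-2-methoxyphenyl on a saturated chain carbon bound to an aromatic nitrogen gives a 1.9-fold higher number from compound 2 to compound 4 (0.27 log units; within the scatter), so this exchange does not separate the two compounds beyond the scatter. For the compounds shown here, this is the first measured step that isolates a change in one place, and it shows that this place can lose the chlorine and the methoxy group and take a propoxy group without a difference that can be read in this measurement. No measurement shown explains the result or bears on what governs clearance at this place.

Going by these compounds alone, the single step changes the substituents on the phenyl ring all at once, so the contributions of losing the chlorine, losing the methoxy group and gaining the propoxy group remain unresolved. Going by these compounds, with compound 2 at 83 mL.min-1.g-1 in this assay, also open is whether an amine, a carboxylic acid or a chain longer than propoxy at this place would give a step beyond the scatter.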